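The source may hold more compounds than are shown below. What is called first, only, known or untested is meant among the compounds shown, and "the series" means these compounds.

Measured compounds in an assay on isolated protein for inhibition of Amine oxidase [flavin-containing] A (Homo sapiens), read by fluorescence, with a stated time of 30 min; on this read-out lower numbers stand for stronger inhibition and higher numbers for weaker inhibition:

- compound 1 `CCN(CCCn1sc2cc(OC)c(OC)cc2c1=O)Cc1ccccc1N(C)C` gives 16600 nM
- compound 2 `CCN(CCCn1sc2cc(OC)c(OC)cc2c1=O)Cc1ccc(N(C)C)cc1` gives 11300 nM
- compound 3 `CCN(CCCCn1sc2cc(OC)c(OC)cc2c1=O)Cc1ccccc1N(C)C` gives 9900 nM

The three measured values lie within the scatter of one another. The change from compound 1 to compound 2 is 4-(dimethylamino)phenyl in place of 2-(dimethylamino)phenyl on a saturated chain carbon bound to an amine nitrogen; it gave a 1.5-fold lower number from compound 1 to compound 2 (0.17 log units; within the scatter). Compound 4 `CCN(CCCCn1sc2cc(OC)c(OC)cc2c1=O)Cc1ccc(N(C)C)cc1` is not yet measured in this assay. It differs from compound 3 by 4-(dimethylamino)phenyl in place of 2-(dimethylamino)phenyl on a saturated chain carbon bound to an amine nitrogen, the same change at the same place. The cores of compound 1 and compound 3 differ, and that difference is not broken down here. For compound 4 a step of similar size is expected, a 1.4-fold lower number from compound 3 to compound 4 (0.15 log units; within the scatter), because the same change earlier gave a 1.5-fold lower number from compound 1 to compound 2 (0.17 log units; within the scatter). Compound 4 is estimated at 7000 nM, between 3500 nM and 14000 nM.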

Compound 4, half-maximal inhibitory concentration: 15900 nM
Compound 4: the middle estimate sits 2.3-fold (0.36 log units) below what was measured, and the stated range ends below it.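

On the core of compound 3, 4-(dimethylamino)phenyl in place of 2-(dimethylamino)phenyl gives a 1.6-fold higher number from compound 3 to compound 4 (0.21 log units; within the scatter) in this assay. On these two cores, the change therefore has no effect that can be told from the scatter, and this pair adds no sign that the core governs its outcome. It also does not show that the change carries over reliably, since neither step is large enough to test this, and the two steps cannot be told apart: the same change on two cores in this assay, a 1.5-fold lower number (0.17 log units; within the scatter) from compound 1 to compound 2 and a 1.6-fold higher number (0.21 log units; within the scatter) from compound 3 to compound 4, 2.4-fold (0.37 log units) apart, within the scatter of two such steps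

The compounds shown leave open whether any change to this aryl group moves the number beyond the scatter. A morpholine in place of the dimethylamino group, or an unsubstituted phenyl, would bear on that question.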